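Compound 2 to compound 3: trifluoromethyl replaced by hydrogen

A few compounds are considered here, and "the series" means these few. Any claim that something is new, unique, unknown or untested is made for them only; others in the source may bear on it.

Compound 1 `O=C(NCc1ccc(S(=O)(=O)c2ccccc2)cc1)c1cc2ccncc2s1`: 21%
Compound 2 `O=C(NCc1ccc(S(=O)(=O)c2cccc(C(F)(F)F)c2)cc1)c1cnc2nccn2c1`: 27%

In an ADME assay on microsomes from liver (Mus musculus) for metabolic stability, read by LC-MS, with a stated time of 30 min, tested at 1 uM (a higher number here means that more of the compound is left, a lower number that less of the compound is left), compound 2 gives 27%. That lies within the scatter of compound 1 at 21%, so the two cannot be told apart on these numbers.

Compound 3 `O=C(NCc1ccc(S(=O)(=O)c2ccccc2)cc1)c1cnc2nccn2c1` has not yet been measured. It differs from compound 2 in one place: hydrogen in place of trifluoromethyl on an aromatic carbon, which in words is hydrogen in place of trifluoromethyl on an aromatic carbon, or 3-(trifluoromethyl)phenyl to phenyl.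

Going by the values given here, no measured pair shows this change alone. Compound 1 also carries phenyl and gives 21%, though the core of compound 1 is different. On that basis, the estimated step of a number 1 percentage points higher from compound 2 to compound 3 (within the scatter) is expected to stay within the scatter, with no clear direction. For compound 3 the expected value in this assay is 28%, with an estimated range from 14% to 46%.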

Compound 3, percent of the compound remaining: 30%
Estimate against measurement, compound 3: 2 percentage points below; the measured number falls inside the stated range.
By their numbers in this assay, from the lowest: compounds 1, 2 and 3 (each within the scatter of the next).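

In this assay, going by these compounds alone, hydrogen in place of trifluoromethyl on an aromatic carbon gives a number 3 percentage points higher from compound 2 to compound 3 (within the scatter), so this change, now seen alone for the first time, has no effect that can be told from the scatter. With phenyl held constant, exchanging the core of compound 1 for the core shared by compound 2 and compound 3 gives a number 9 percentage points higher from compound 1 to compound 3 (within the scatter), so these two cores cannot be told apart on this read-out either. Nothing available explains either result.

As far as these compounds go, only trifluoromethyl and hydrogen are seen at this place, so it remains open whether a methoxy group, an amine or a carboxylic acid there would shift the percentage remaining beyond the scatter. From the compounds shown here alone, it also remains open whether trifluoromethyl would behave the same way on the core of compound 1.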